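This account rests on a few compounds, and the source may have more. Where it says the series, first, only, none or still open, it means among the compounds named here.

Series notes. Compound 1 `CCc1c[nH]c2ncnc(N[C@H]3CC[C@H](N(C)C)CC3)c12` and compound 2 `CN(C)[C@H]1CC[C@H](Nc2ncnc3[nH]cc(C(F)(F)F)c23)CC1` share a core and differ only in the group on an aromatic carbon of the five-membered aromatic ring; compound 3 `CN(C)[C@H]1CC[C@H](Nc2ncnc3[nH]cc(C4CC4)c23)CC1` varies the same carbon and has not yet been measured. For the measured compounds named here, in an ADME assay on cells (Hepatocyte, Rattus norvegicus) for metabolic stability (a higher number here means faster removal of the compound, a lower number slower removal), compound 1 gives 29 uL/min and compound 2 gives 66 uL/min, the higher of the two numbers so far; the step of a 2.3-fold higher number from compound 1 to compound 2 (0.36 log units; beyond the scatter) is the only measured step in the set. Compound 3 differs from compound 2 by cyclopropyl in place of trifluoromethyl on an aromatic carbon. Going by the values given here, no measured step covers this exact exchange; the only one that bears on it is a 2.3-fold higher number from compound 1 to compound 2 (0.36 log units; beyond the scatter). The entering cyclopropyl, three carbons and no fluorine, is closer in make-up to the ethyl of compound 1 than to the trifluoromethyl of compound 2, so a step back toward the number of compound 1, of roughly the size of that step but in the other direction, is expected. For compound 3 the expected step is a 1.9-fold lower number from compound 2 to compound 3 (0.28 log units; within the scatter). The estimate for compound 3 in this assay is 35 uL/min, with a range of 18 uL/min to 70 uL/min.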

Compound 3, intrinsic clearance in a liver preparation (reported as CLH), per the amount of preparation that the assay uses in the Hepatocyte assay: 15 uL/min
For compound 3 the middle estimate is 2.3-fold (0.37 log units) above the measured one, outside the stated range (below it).
By their numbers in the Hepatocyte assay, from the lowest: compounds 3 and 1 (each within the scatter of the next); then compound 2.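

At this aromatic carbon, cyclopropyl in place of trifluoromethyl gives in the Hepatocyte assay a 4.4-fold lower number from compound 2 to compound 3 (0.64 log units; beyond the scatter), so among the three groups shown trifluoromethyl is the one that stands apart. Cyclopropyl in place of ethyl gives in the Hepatocyte assay a 1.9-fold lower number from compound 1 to compound 3 (0.29 log units; within the scatter), so a ring of three carbons and an open ethyl are not separated on this read-out. In a physicochemical assay for lipophilicity, using the shake flask method, at pH 7.4 (on this read-out lower numbers stand for lower lipophilicity and higher numbers for higher lipophilicity), compound 2 gives 1.5 and compound 3 gives 0.9, so for this pair faster removal goes with higher lipophilicity, though a single pair cannot separate that link from any other difference between the two groups: the measured distribution coefficient of compound 2, 1.5, and of compound 3, 0.9, a number 0.60 log units lower (beyond the scatter).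

Open, from the compounds shown here alone, is where a nitrile, a methoxy group or a longer chain such as propyl on this carbon would fall in the Hepatocyte assay relative to ethyl, cyclopropyl and trifluoromethyl. Also open, going by these compounds, is whether removal follows the distribution coefficient beyond this one pair, or whether the link is particular to trifluoromethyl and cyclopropyl.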